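The source may report more compounds than this note shows. Statements on the series, on what has been measured and on what is new or still open speak of the compounds shown alone.

Measured compounds: compound 1 `COc1cc(O)c(C(=O)/C=C/c2ccc(F)cc2)c(OC)c1` gives 28% in a functional assay on HCT-116 cells (Homo sapiens), read by fluorescence and BrdU incorporation, with a stated time of 48 h, tested at 25 uM; a higher number here means a weaker effect of the compound at the concentration tested, a lower number a stronger effect; compound 2 `COc1cc(OC)c(C(=O)/C=C/c2ccccc2SC)c(OC)c1` gives 0.5%.

Compound 2 stands lowest of the two numbers, its nearest neighbour being compound 1, whose value lies higher by a gap beyond the scatter; the two compounds differ in more than one place, so their pair shows only what the two values show. Compound 3 `COc1cccc(/C=C/C(=O)c2c(OC)cc(OC)cc2OC)c1` has not yet been measured in this assay. It differs from compound 2 in one place: 3-methoxyphenyl in place of 2-(methylsulfanyl)phenyl on a double-bonded chain carbon bound to a double-bonded chain carbon. Going by the values given here, no single-point step between measured compounds is available here, so the expected effect of this change rests on the standing of compound 2 alone. Compound 3 is expected to keep much of the strong effect of compound 2 because of 0.5%, with a moderate rise in the number as the likelier direction, so the expected step of a number 14.5 percentage points higher from compound 2 to compound 3 (beyond the scatter) is upward. Compound 3 is estimated at 15%, within a range from 1% to 55%.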

Compound 3, a percentage reported as activity, at one concentration (the size of the read-out at that concentration, not a potency): 0.6%
The estimate for compound 3 lay 14.4 percentage points above the measured number; measured number outside the range, below it.
By their numbers in this assay, from the lowest: compounds 2 and 3 (each within the scatter of the next); then compound 1.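

Putting 3-methoxyphenyl in place of 2-(methylsulfanyl)phenyl on a double-bonded chain carbon bound to a double-bonded chain carbon gives a number 0.1 percentage points higher from compound 2 to compound 3 (within the scatter) in this assay. At this position, then, the sulfur-bearing group is not needed to keep the number as low as that of compound 2, and an oxygen-bearing group, with the same count of heavy atoms and hydrogen-bond acceptors, serves as well. Nothing available explains why the two groups read alike.

The compounds shown leave open whether this position would tolerate a ring carrying an amine or a carboxylic acid in place of these groups. With compound 2 and compound 3 both so low, they also leave open whether a single concentration could separate further changes here.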